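The source may hold more compounds than are shown below. What is called first, only, known or untested is meant among the compounds shown, and "the series" means these compounds.

Working notes on the series. Compound 1 `O=C(NCc1cccc(Cl)c1)c1ccc2cn(CCn3cccn3)nc2c1` gives 173 nM in an assay on isolated protein for inhibition of thyroid hormone receptor beta (Homo sapiens), read by fluorescence, with a stated time of 30 min; a lower number here means a stronger inhibitor, a higher number a weaker inhibitor. Within the data shown here, compound 2 `CCCN(CC1CCOC1)C(=O)c1cc(Cl)c2oc(NCc3cccc(Cl)c3)nc2c1` gives 71 nM in this assay, and compound 3 `CCCN(CC1CCOC1)C(=O)c1cc(C)c2oc(NCc3cccc(Cl)c3)nc2c1` gives 35 nM in this assay, the lowest of the three numbers measured so far. Among the measured compounds shown here, the step of a 2.0-fold lower number from compound 2 to compound 3 (0.31 log units; beyond the scatter) is the only single-point change measured to date. Compound 4 `CCCN(CC1CCOC1)C(=O)c1cc(CC)c2oc(NCc3cccc(Cl)c3)nc2c1` carries the change (methyl in place of hydrogen on a saturated chain carbon bound to an aromatic carbon), so the group on the aromatic carbon of compound 3 grows from methyl to ethyl. For the measured compounds named here, no measured step alters this carbon: the step from compound 2 to compound 3 exchanged the group on an aromatic carbon rather than on a saturated chain carbon, and that step was itself modest. The three measured compounds show that changes on the shared core have moved the number only over a narrow span, but none of them adds a carbon at this place, so the direction of the coming step is not fixed by the data. The expectation is a step of a 1.1-fold higher number from compound 3 to compound 4 (0.06 log units; within the scatter), small enough to sit inside the usual scatter. Compound 4 is therefore estimated at 40 nM in this assay, with a range from 18 nM to 90 nM.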

Compound 4, half-maximal inhibitory concentration: 104 nM
The estimate for compound 4 lay 2.6-fold (0.41 log units) below the measured number, and the stated range ends below it.
By their numbers in this assay, from the lowest: compound 3; then compounds 2, 4 and 1 (each within the scatter of the next, the first and the last beyond it).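

Growing methyl to ethyl on this aromatic carbon is the first measured change to the saturated chain there, and in this assay it gives a 3.0-fold higher number from compound 3 to compound 4 (0.47 log units; beyond the scatter), so the number responds to the single added carbon at this place. The exchange of chloro for ethyl gives a 1.5-fold higher number from compound 2 to compound 4 (0.17 log units; within the scatter), leaving these two groups unresolved in this assay, whereas methyl stands apart from both by steps beyond the scatter, so among the three groups compared on this carbon, the number does not follow a simple trend with the size of the group. No measurement in hand bears on the reason for the step to ethyl.

The compounds shown leave open whether the number rises further with a longer chain such as propyl, and how a branched group such as isopropyl, a ring such as cyclopropyl, or a methoxy group would read on this carbon. From the compounds shown here alone, all three groups were compared with the same propyl and tetrahydrofuranylmethyl amide and the same 3-chlorobenzylamine, so whether the preference for methyl holds once those parts change also stays open.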